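The source may hold more compounds than are shown below. What is called first, only, known or untested is meant among the compounds shown, and "the series" means these compounds.

Measured in a functional assay on B16-F10 cells (Mus musculus) for antiproliferative activity, read by ELISA and MTT assay, with a stated time of 48 h; on this read-out lower numbers stand for stronger inhibition and higher numbers for weaker inhibition:
compound 1, `O=C(/C=C/c1ccccc1)NS(=O)(=O)c1ccc(Cl)cc1`: 2.2 ug/mL
compound 2, `O=C(/C=C/c1ccc(Cl)cc1)NS(=O)(=O)c1ccc(Cl)cc1`: 2.5 ug/mL
compound 3, `COc1ccc(/C=C/C(=O)NS(=O)(=O)c2ccc(F)cc2)cc1`: 5.1 ug/mL

Compound 3 gives the highest number of the three in this assay; its gaps to compound 2 and to compound 1 both lie beyond the scatter. Compound 4, `COc1ccc(/C=C/C(=O)NS(=O)(=O)c2ccc(Cl)cc2)cc1`, differs from compound 3 in one place: chloro in place of fluoro on an aromatic carbon. Going by the values given here, no measured pair shows this exchange directly. Among the compounds with values here, the one single-place step on record, a 1.1-fold higher number from compound 1 to compound 2 (0.06 log units; within the scatter), concerns a different exchange at a different place and lies within the scatter. Compound 1 and compound 2 both give lower numbers than compound 3. For compound 4 the expected step is a 1.5-fold lower number from compound 3 to compound 4 (0.16 log units; within the scatter), a modest downward step that may not clear the scatter. Compound 4 is estimated at 3.5 ug/mL, with a range from 1.8 ug/mL to 7 ug/mL.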

Compound 4, half-maximal inhibitory concentration: 5.3 ug/mL
The estimate for compound 4 lay 1.5-fold (0.18 log units) below the measured number; the range from low to high includes it.
By their numbers in this assay, from the lowest: compounds 1 and 2 (each within the scatter of the next); then compounds 3 and 4 (each within the scatter of the next).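

In this assay the direct exchange of 4-fluorophenyl for 4-chlorophenyl gives a 1.0-fold higher number from compound 3 to compound 4 (0.02 log units; within the scatter), so with methoxy on the shared core these two halogens stay within the scatter of each other. With 4-chlorophenyl held constant, methoxy in place of chloro gives a 2.1-fold higher number from compound 2 to compound 4 (0.33 log units; beyond the scatter) and methoxy in place of hydrogen gives a 2.4-fold higher number from compound 1 to compound 4 (0.38 log units; beyond the scatter), both modest steps beyond the scatter. No measurement on hand accounts for these steps.

Open, as far as these compounds go, is whether an amine or a carboxylic acid in place of the halogen would separate from compound 3 and compound 4.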